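The compounds below may be only part of what the source reports. "The series", "measured", "known", "first", "only" and "open" are said of these compounds alone.

In an ADME assay on L1210 cells (Mus musculus) for cytotoxicity, with a stated time of 48 h (on this read-out lower numbers stand for stronger inhibition and higher numbers for weaker inhibition), compound 1 `CC1=CCC[C@](C)(CC/C(C)=C/CC2=C(O)C(=O)C=C(N[C@@H](C(=O)O)[C@@H](C)O)C2=O)[C@@H]1C` gives > 10 ug/mL, a limit and not a number. Compound 2 `CC1=CCC[C@](C)(CC/C(C)=C/CC2=C(O)C(=O)C=C(N[C@@H](C(=O)O)[C@H](C)O)C2=O)[C@@H]1C` gives > 10 ug/mL, likewise a limit. Going by the values given here, the only measured comparison is a step that the two limits leave unreadable from compound 1 to compound 2, which offers no size to carry over because of the limit of > 10 ug/mL in this assay, at which 2 of the 2 values shown sit. Compound 3 `CC1=CCC[C@](C)(CC/C(C)=C/CC2=C(O)C(=O)C=C(NCC(=O)O)C2=O)[C@@H]1C` differs from compound 2 by hydrogen in place of 1-hydroxyethyl on a saturated chain carbon bound to an amine nitrogen and a carbonyl carbon, with hydrogen in place of 1-hydroxyethyl on a saturated chain carbon bound to an amine nitrogen and a carbonyl carbon. No direction can be read from these data, so nothing beyond the scatter is assumed. The expected change is a step that the limit leaves unreadable from compound 2 to compound 3. Compound 3 is estimated at 12 ug/mL, with an expected range of 5 ug/mL to 25 ug/mL.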

Compound 3, half-maximal inhibitory concentration: 3.5 ug/mL
Estimate against measurement, compound 3: 3.4-fold (0.54 log units) above; the whole stated range lies above it.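

Working from this assay, hydrogen in place of 1-hydroxyethyl on a saturated chain carbon bound to an amine nitrogen and a carbonyl carbon gives an at least 2.8-fold lower number from compound 2 to compound 3 (0.45 log units; beyond the scatter), and likewise an at least 2.8-fold lower number from compound 1 to compound 3 (0.45 log units; beyond the scatter). Going by these compounds alone, these are the first readable steps, and they show that this place registers on the read-out from either drawn configuration of the 1-hydroxyethyl. The step between the two configurations itself still cannot be read: the limit of > 10 ug/mL in this assay, at which 2 of the 3 values shown sit.

On these data alone, whether the step belongs to the hydroxyl or to the carbons of the 1-hydroxyethyl stays open. As far as these compounds go, how a methyl or an ethyl at this place would read also stays open.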